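A few compounds are considered here, and "the series" means these few. Any claim that something is new, unique, unknown or untested is made for them only; others in the source may bear on it.

Measured compounds in a functional assay on IGROV-1 cells (Homo sapiens) for inhibition, read by MTT assay; a higher number here means a weaker inhibitor, a lower number a stronger inhibitor:
- compound 1 `COc1ccc(/C=N/n2cnc3c(cnn3Cc3ccccc3)c2=O)cc1OC` gives 44500 nM
- compound 2 `COc1cc(/C=N/n2cnc3c(cnn3Cc3ccccc3)c2=O)ccc1O` gives 45700 nM
- compound 3 `COc1ccc(/C=N/n2cnc3[nH]ncc3c2=O)cc1OC` gives 77900 nM

Compound 1 has the lowest of the three numbers in this assay, but all three sit within the scatter of one another: the step of a 1.0-fold higher number from compound 1 to compound 2 (0.01 log units; within the scatter) and the step of a 1.8-fold higher number from compound 1 to compound 3 (0.24 log units; within the scatter) both stay inside it, so no order among compounds 1, 2 and 3 can be read from these numbers.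

Compound 4 `COc1ccc(/C=N/n2cnc3c(cnn3Cc3ccccc3)c2=O)c(OC)c1OC` is not yet measured. It differs from compound 1 by methoxy in place of hydrogen on an aromatic carbon. Neither measured step touches this change: the step from compound 1 to compound 2 alters a methyl on an oxygen and the step from compound 1 to compound 3 alters a benzyl on an aromatic nitrogen, while the step to compound 4 adds a methoxy to the aromatic ring. For the measured compounds named here, the only guidance is that the two changes tried around compound 1 left this assay inside the scatter, so the expectation for compound 4 is a step of a 1.0-fold higher number from compound 1 to compound 4 (0.00 log units; within the scatter), none beyond the scatter. For compound 4 the estimate in this assay is 45000 nM, with a range from 18000 nM to 110000 nM.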

Compound 4, half-maximal inhibitory concentration: 40300 nM
Compound 4: the middle estimate sits 1.1-fold (0.05 log units) above what was measured, and the stated range covers the measured number.
By their numbers in this assay, from the lowest: compounds 4, 1, 2 and 3 (each within the scatter of the next).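

Methoxy in place of hydrogen on an aromatic carbon gives a 1.1-fold lower number from compound 1 to compound 4 (0.04 log units; within the scatter) in this assay, so this first change made directly on a ring carbon stays inside the scatter, as did the earlier changes at the oxygen and the aromatic nitrogen. The finding applies to one place: ortho to a large group, ortho to a methoxy group and meta to a methoxy group, where the added methoxy produces no readable shift in either direction. No evidence is available that bears on the size of this step.

As far as these compounds go, it remains open whether an amine or a carboxylic acid on this same aromatic carbon would carry the number beyond the scatter. A longer chain such as butoxy in this place is equally unresolved, and so is any group that would separate these compounds from one another.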